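This account rests on a few compounds, and the source may have more. Where it says the series, first, only, none or still open, it means among the compounds named here.

Measured in an ADME assay on a cell-free system (plasma, Homo sapiens) for metabolic stability (a higher number here means that the compound lasts longer, a lower number that the compound disappears faster), read as half-life:
compound 1 `C[C@@H]1[C@H](C)[C@@H]1C(=O)N1C(=O)[C@@H](C)[C@@H]2[C@@H]1CCN2C(=O)[C@@H]1CCCN1S(=O)(=O)c1cccc2c(N(C)C)cccc12`: 20 h
compound 2 `C[C@@H]1C(=O)N(C(=O)C2C(C)(C)C2(C)C)[C@H]2CCN(C(=O)[C@@H]3CCCN3S(=O)(=O)c3cccc4c(N(C)C)cccc34)[C@H]12`: > 24 h, a limit
compound 3 `C[C@@H]1C(=O)N(c2nccs2)[C@H]2CCN(C(=O)[C@@H]3CCCN3S(=O)(=O)c3cccc4c(N(C)C)cccc34)[C@H]12`: not yet measured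

Compound 2 stands at a limit of the assay, > 24 h, and not at a number. The next change is 1,3-thiazol-2-yl in place of (2,2,3,3-tetramethylcyclopropyl)carbonyl on an amide-type nitrogen in a ring. Going by the values given here, only one measured step bears on it, and only loosely: an at least 1.2-fold higher number from compound 1 to compound 2 (0.07 log units; that floor lies within the scatter) keeps the carbonyl and stays within the scatter. Among the compounds with values here, no measured step removes that carbonyl. In this assay the expected step is a number no higher from compound 2 to compound 3 (the limit leaves the size open), with no shift beyond the scatter expected in either direction. For compound 3 the estimate is 24 h, with an expected range of 12 h to 48 h.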

Compound 3, half-life: > 50 h
Compound 3 ended at the assay's limit; the forecaster's own chance of this, stated with the estimate: 60%; at least 2.0-fold (0.31 log units) between middle value and limit.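

In this assay compound 3 gives > 50 h, a limit and not a number. Going by these compounds alone, on the amide-type nitrogen in a ring, the carbonyl can go without loss of half-life: 1,3-thiazol-2-yl in place of (2,3-dimethylcyclopropyl)carbonyl gives an at least 2.5-fold higher number from compound 1 to compound 3 (0.39 log units; beyond the scatter), the only readable step here beyond the scatter. Compound 2 and compound 3 both stand at limits, and the step between them cannot be read.

As far as these compounds go, the true half-life of compound 3 remains open. So does whether a phenyl or a 1,3-oxazol-2-yl on that nitrogen would behave like 1,3-thiazol-2-yl.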